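A Larger Amine Group on a Weak Compound

This account rests on a few compounds, and the source may have more. Where it says the series, first, only, none or still open, it means among the compounds named here.

Compound 2 `CCCNC(=C\C(=O)/C=C/c1ccc(O)c(OC)c1)/C=C/c1ccc(O)c(OC)c1` reads > 25000 nM in a functional assay on Caco-2 cells (Homo sapiens) for inhibition, read by MTT assay, with a stated time of 72 h (on this read-out higher numbers stand for weaker inhibition and lower numbers for stronger inhibition), and that is a limit of the assay, not a number. Compound 3 `COc1cc(/C=C/C(=O)CC(=O)/C=C/c2ccc(OC(C)=O)c(OC)c2)ccc1OC(C)=O` shows > 25000 nM in this assay and this too is a limit. Compound 1 `COc1cc(/C=C/C(=O)/C=C(/C=C/c2ccc(OC(C)=O)c(OC)c2)NC2CCCCC2)ccc1OC(C)=O` also carries cyclohexyl on the amine nitrogen and gives 9700 nM in this assay as a true number. Compound 4 `COc1cc(/C=C/C(=O)/C=C(/C=C/c2ccc(O)c(OC)c2)NC2CCCCC2)ccc1O` differs from compound 2 by one change, cyclohexyl in place of propyl on an amine nitrogen with cyclohexyl in place of propyl on an amine nitrogen. A moderate move toward stronger inhibition in this assay is expected, resting on compound 1 at 9700 nM in that test. The expected step of an at least 1.6-fold lower number from compound 2 to compound 4 (0.22 log units; that floor lies within the scatter) remains rough, since compound 2 has no exact number. Compound 4 is estimated at 15000 nM with an expected range from 6000 nM to 30000 nM overall.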

Compound 4, half-maximal inhibitory concentration: > 25000 nM
Compound 4: only a limit was reported; the forecaster's own chance of this, stated with the estimate: 35%; middle value at least 1.6-fold (0.22 log units) from the limit.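

For the compounds shown here, compound 2 and compound 4 both stop at a limit of the assay rather than a number, so no step between them can be read: the limit of > 25000 nM in this assay, at which 3 of the 4 values shown sit. Going by these compounds, whether cyclohexyl in place of propyl on an amine nitrogen changes inhibition at all remains open.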